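Clearance notes: from compound 2 to compound 3

The source may hold more compounds than are shown below. What is called first, only, known or untested is meant among the compounds shown, and "the series" means these compounds.

Measured in an in vitro ADME assay on microsomes from liver (Homo sapiens) for pharmacokinetics, read by LC-MS, with a stated time of 10 min, tested at 1 uM; on this read-out higher numbers stand for fast clearance and lower numbers for slow clearance:
- compound 1 `Cc1cc(NC(=O)[C@H]2CN(C)C[C@@H]2c2ccc(/C=C/C(=O)Nc3ccccc3N)cc2)ccc1F` gives 15 mL/min/kg
- compound 2 `Cc1cc(NC(=O)[C@H]2CN(C)C[C@@H]2c2ccc(/C=C/C(=O)Nc3ccccc3N)cc2)ccc1Cl` gives 15 mL/min/kg

Compound 2 stands level with compound 1 at the digits shown. Compound 3 `Cc1ccc(NC(=O)[C@H]2CN(C)C[C@@H]2c2ccc(/C=C/C(=O)Nc3ccccc3N)cc2)cn1` carries 6-methylpyridin-3-yl in place of 4-chloro-3-methylphenyl on an amide-type nitrogen. For the measured compounds named here, the one measured step shows no change at the digits printed from compound 1 to compound 2 (within the scatter) for chloro in place of fluoro on an aromatic carbon. That step does not cover an exchange of the whole ring, so it gives no direction. No step beyond the scatter is expected in this assay, and the estimated step is a 1.2-fold lower number from compound 2 to compound 3 (0.06 log units; within the scatter). The expected value for compound 3 is 13 mL/min/kg, with a range from 6 mL/min/kg to 25 mL/min/kg.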

Compound 3, clearance: 8 mL/min/kg
Compound 3: middle estimate off by 1.6-fold (0.21 log units), on the high side, and the stated range covers the measured number.
By their numbers in this assay, from the lowest: compounds 3, 1 and 2 (each within the scatter of the next).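

In this assay, 6-methylpyridin-3-yl in place of 4-chloro-3-methylphenyl on the amide-type nitrogen gives a 1.9-fold lower number from compound 2 to compound 3 (0.27 log units; within the scatter), and in place of 4-fluoro-3-methylphenyl it gives a 1.9-fold lower number from compound 1 to compound 3 (0.27 log units; within the scatter). The whole aromatic ring at this position can therefore be exchanged for one with a hetero atom and a hydrogen-bond acceptor without a step beyond the scatter, which the chloro and fluoro exchange could not show. Nothing measured here bears on a cause for these steps. Going by these compounds, whether a dimethylamino group or a carboxylic acid on this ring would give a step beyond the scatter remains open.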